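A few compounds are considered here, and "the series" means these few. Any claim that something is new, unique, unknown or untested is made for them only; others in the source may bear on it.

Compound 1, `COc1cc(-c2ccnc3cc(-c4ccc(Cl)cc4)nn23)cc(OC)c1OC`, carries a 4-chlorophenyl group on the shared core. In a functional assay on HeLa cells (Homo sapiens) for inhibition, read by CCK-8 assay, with a stated time of 48 h (on this read-out lower numbers stand for stronger inhibition and higher numbers for weaker inhibition), compound 1 gives 1490 nM, the highest of the two plain numbers; its nearest neighbour is compound 3, `COc1cc(-c2ccnc3cc(-c4cn(C)c5ccccc45)nn23)cc(OC)c1OC`, with 399 nM, a step of a 3.7-fold lower number from compound 1 to compound 3 (0.57 log units; beyond the scatter). Compound 2, `COc1cc(-c2ccnc3cc(-c4cccc(C#N)c4)nn23)cc(OC)c1OC`, gives > 10000 nM, which is a limit rather than a number. Compound 4, `COc1cc(-c2ccnc3cc(-c4ccc(C(C)=O)cc4)nn23)cc(OC)c1OC`, differs from compound 1 by acetyl in place of chloro on an aromatic carbon. The step from compound 1 to compound 2 is the only measured one that keeps the phenyl ring and changes only its substituent, and it was an at least 6.7-fold higher number from compound 1 to compound 2 (0.82 log units; beyond the scatter). Compound 4 likewise swaps the chloro for a group bringing one hydrogen-bond acceptor, so a rise in number beyond the scatter is expected, about a 3.0-fold higher number from compound 1 to compound 4 (0.48 log units; beyond the scatter). Compound 4 is therefore estimated at 4500 nM, between 1500 nM and 12000 nM.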

Compound 4, half-maximal inhibitory concentration: 1810 nM
For compound 4 the middle estimate is 2.5-fold (0.40 log units) above the measured one; the measured number falls inside the stated range.
By their numbers in this assay, from the lowest: compound 3; then compounds 1 and 4 (each within the scatter of the next). At a limit, above all of these: compound 2.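

Acetyl in place of chloro, para to a large group, makes no change beyond the scatter: a 1.2-fold higher number from compound 1 to compound 4 (0.08 log units; within the scatter). The hydrogen-bond acceptor that acetyl brings therefore does not by itself raise the number, though 4-acetylphenyl still trails 1-methyl-1H-indol-3-yl, with a 4.5-fold higher number from compound 3 to compound 4 (0.66 log units; beyond the scatter). Against 3-cyanophenyl the step is an at least 5.5-fold lower number from compound 2 to compound 4 (0.74 log units; beyond the scatter), and it is read from a limit rather than a number.

Going by these compounds, whether an amine or a carboxylic acid at this same place would match acetyl and chloro remains open. So does whether acetyl would keep this level on a different carbon of the phenyl ring.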